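Fluoro to chloro on the furan-3-yl compound

The compounds below may be only part of what the source reports. "The series", "measured", "known", "first", "only" and "open" are said of these compounds alone.

Values in a functional assay on CCRF-CEM cells (Homo sapiens) for cytotoxicity, read by XTT assay, with a stated time of 3 days (a higher number here means a weaker inhibitor, a lower number a stronger inhibitor), so far:
compound 1 `OC[C@H]1O[C@@H](n2cc(F)c3c(-c4cccs4)ncnc32)[C@H](O)[C@@H]1O` gives 270 nM
compound 2 `OC[C@H]1O[C@@H](n2cc(F)c3c(-c4ccc[nH]4)ncnc32)[C@H](O)[C@@H]1O` gives 410 nM
compound 3 `OC[C@H]1O[C@@H](n2cc(F)c3c(-c4ccoc4)ncnc32)[C@H](O)[C@@H]1O` gives 1000 nM

Among these three, compound 3 has the highest number and is the weakest. The next compound is compound 4 `OC[C@H]1O[C@@H](n2cc(Cl)c3c(-c4ccoc4)ncnc32)[C@H](O)[C@@H]1O`, which keeps the furan-3-yl group and differs from compound 3 as follows: chloro in place of fluoro on an aromatic carbon.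

The measured steps all exchange the thiophen-2-yl, 1H-pyrrol-2-yl and furan-3-yl groups while fluoro stays. The first, a 1.5-fold higher number from compound 1 to compound 2 (0.18 log units; within the scatter), is small, while a 3.7-fold higher number from compound 1 to compound 3 (0.57 log units; beyond the scatter) and a 2.4-fold higher number from compound 2 to compound 3 (0.39 log units; beyond the scatter) are modest. None of them replaces fluoro, so the new change has no direct measure, and these steps offer only a rough guide to size across three compounds. A step no larger than these is expected, and the data give no firm direction. A slight lean towards a lower number is taken, without expecting a move beyond the scatter. The expected step is a 1.4-fold lower number from compound 3 to compound 4 (0.15 log units; within the scatter) on this estimate. Compound 4 is estimated at 700 nM with an expected range of 250 nM to 2000 nM for now.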

Compound 4, half-maximal inhibitory concentration: 1100 nM
Beside the measured number, compound 4's estimate is 1.6-fold (0.20 log units) below it; the measured number falls inside the stated range.
By their numbers in this assay, from the lowest: compounds 1 and 2 (each within the scatter of the next); then compounds 3 and 4 (each within the scatter of the next).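

In this assay, among the compounds shown here, the first direct reading at this position gives a 1.1-fold higher number from compound 3 to compound 4 (0.04 log units; within the scatter), so with the furan-3-yl group in place, fluoro and chloro on this aromatic carbon of the five-membered ring cannot be told apart. The earlier steps shown here all held fluoro fixed and changed only the other group, and one of them, a 3.7-fold higher number from compound 1 to compound 3 (0.57 log units; beyond the scatter), lies beyond the scatter, so in these four compounds a clear shift has come only from that exchange and none from the halogen exchange, which adds one heavy atom for one heavy atom with no change in the hydrogen-bond donor or acceptor counts. No measurement at hand accounts for this flat result or shows whether it extends beyond this single pair.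

As far as these compounds go, this reading rests on one pair, so it remains open whether chloro in place of fluoro would be equally silent with the thiophen-2-yl or 1H-pyrrol-2-yl group, the two with the lower numbers. From the compounds shown here alone, it is also open how far the position tolerates groups other than these two halogens, such as a methyl, a nitrile or an amine on the same carbon.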